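Benzisoxazole acids with a varied pendant group

A few compounds are considered here, and "the series" means these few. Any claim that something is new, unique, unknown or untested is made for them only; others in the source may bear on it.

The two measured compounds share a core carrying an acid and a pendant aryl group. Compound 1 `O=C(O)/C=C/c1ccc2noc(-c3ccc(-c4ccccc4)cc3)c2c1` is the stronger of the pair: in an assay for inhibition of inositol hexakisphosphate kinase 3 (Homo sapiens), read by colorimetric assay, coupled enzyme assay and malachite green, with a stated time of 120 min, in the presence of a further agent that is not named here (on this read-out lower numbers stand for stronger inhibition and higher numbers for weaker inhibition), compound 1 gives 200 nM. Compound 2 `O=C(O)c1ccc2noc(-c3ccc(Cc4ccccc4)cc3)c2c1` has a shorter acid arm and a benzyl substituent, and in this assay compound 2 gives 1290 nM, the highest number of the two and well beyond the scatter from compound 1.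

Compound 3 `O=C(O)c1ccc2noc(-c3ccc(NC(=O)C4CCCC4)cc3)c2c1` keeps the acid of compound 2 and changes only the pendant group: (cyclopentylcarbonyl)amino in place of benzyl on an aromatic carbon, on an aromatic carbon para to a large group. Going by the values given here, no measured pair shows this exact exchange, so the expected step is uncertain. A modest improvement from compound 2 is expected, a 2.2-fold lower number from compound 2 to compound 3 (0.33 log units; beyond the scatter), though a result within the scatter would not surprise. Compound 3 is therefore estimated at 600 nM, with a range from 150 nM to 2500 nM.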

Compound 3, half-maximal inhibitory concentration: 240 nM
Beside the measured number, compound 3's estimate is 2.5-fold (0.40 log units) above it; low and high end bracket the measured number.
By their numbers in this assay, from the lowest: compounds 1 and 3 (each within the scatter of the next); then compound 2.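

Going by these compounds alone, with the acid arm held fixed, this is the first reading of the pendant position alone: in this assay, placing (cyclopentylcarbonyl)amino in place of benzyl on an aromatic carbon para to a large group gives a 5.4-fold lower number from compound 2 to compound 3 (0.73 log units; beyond the scatter). At this position, then, a six-membered aromatic ring of carbon only is not needed for the lower number, which comes here with a five-membered non-aromatic ring of carbon only, one hydrogen-bond donor and one hydrogen-bond acceptor. No evidence on why the number falls is available.

The amide link and the cyclopentyl ring enter together, so a benzoylamino or acetylamino group at this position would be needed to tell their shares apart. The compounds shown also leave the acid arm's own contribution unresolved, as compound 1 differs from compound 3 in both the acid arm and the pendant group.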